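From Fluoro to Methoxy on a Shared Core

The source may hold more compounds than are shown below. What is called first, only, known or untested is meant among the compounds shown, and "the series" means these compounds.

Compound 1 `CCCNNC(=O)c1ccc(CNC(=O)c2nc3ccccc3s2)cc1` gives 43.6 nM
Compound 2 `CCCNNC(=O)c1ccc(CNC(=O)c2cc3cc(F)ccc3o2)cc1` gives 56.5 nM

In a functional assay on MV4-11 cells (Homo sapiens) for antiproliferative activity, with a stated time of 48 h (on this read-out higher numbers stand for weaker inhibition and lower numbers for stronger inhibition), compound 2 gives 56.5 nM and compound 1 gives 43.6 nM as its nearest neighbour. For the measured compounds named here, these two values lie within the usual scatter of repeated measurements, so compound 2 stands level with compound 1 on the numbers so far.

Compound 3 `CCCNNC(=O)c1ccc(CNC(=O)c2cc3cc(OC)ccc3o2)cc1` is the next to be tested. It differs from compound 2 in one place, with methoxy in place of fluoro on an aromatic carbon and the rest of the structure unchanged.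

Going by the values given here, no two measured compounds differ in only one place, so nothing measured shows directly what this swap does. The starting point for a forecast is therefore compound 2 at 56.5 nM and, with no evidence for a large shift, the working expectation in this assay is a small change with no firm direction. The expected change is a 1.1-fold higher number from compound 2 to compound 3 (0.03 log units; within the scatter) and this estimate stays within the scatter. For compound 3 the estimated value is 60 nM with an expected range from 25 nM to 140 nM as the likely span.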

Compound 3, half-maximal inhibitory concentration: 52.1 nM
Compound 3: middle estimate off by 1.2-fold (0.06 log units), on the high side; low and high end bracket the measured number.
By their numbers in this assay, from the lowest: compounds 1, 3 and 2 (each within the scatter of the next).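

In this assay, putting methoxy in place of fluoro on this aromatic carbon gives a 1.1-fold lower number from compound 2 to compound 3 (0.04 log units; within the scatter). For the compounds shown here, this is the first direct reading of a single change, and it shows that the assay does not separate these two groups at this position: methoxy has 2 heavy atoms and 1 hydrogen-bond acceptor, fluoro has 1 heavy atom and 0 hydrogen-bond acceptors, and the numbers stay level. No measurement at hand explains why the two groups read alike.

Going by these compounds, a single swap says little about the position as a whole, so it remains open whether an amine, a hydroxyl or a longer chain such as ethoxy on the same aromatic carbon would also leave the number level. On these data alone, it also remains open whether the same swap from fluoro to methoxy would read the same way on the core of compound 1, where the shared side chain is kept but the group carrying this position differs.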